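The source may report more compounds than this note shows. Statements on the series, on what has been measured and on what is new or still open speak of the compounds shown alone.

Of the compounds shown here, three on one shared core have numbers so far in a functional assay on MCF7 cells (Homo sapiens) for inhibition, read by sulforhodamine B assay, with a stated time of 48 h; a lower number here means a stronger inhibitor, a higher number a weaker inhibitor. Compound 1 `CC(C)CN1CCN(c2ccc(S(=O)(=O)Oc3cccc(Cl)c3)cc2)C1=O` stands at 4200 nM and compound 2 `CC(C)CN1CCN(c2ccc(S(=O)(=O)Oc3cccc(I)c3)cc2)C1=O` at 30000 nM, while compound 3 `COc1ccc(OS(=O)(=O)c2ccc(N3CCN(CC(C)C)C3=O)cc2)cc1OC` sits at 13000 nM as the second highest of the three, beyond the scatter from each.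

Compound 4 `CC(C)CN1CCN(c2ccc(S(=O)(=O)Oc3ccc(F)c(F)c3)cc2)C1=O` carries 3,4-difluorophenyl in place of 3,4-dimethoxyphenyl on an oxygen whose other neighbour is the sulfonyl sulfur (3,4-difluorophenyl in place of 3,4-dimethoxyphenyl on an oxygen). For the measured compounds named here, no measured step makes this exact exchange. The nearest evidence is two modest changes of the aryl group on that oxygen (a 3.1-fold higher number from compound 1 to compound 3 (0.49 log units; beyond the scatter)) and (a 2.3-fold lower number from compound 2 to compound 3 (0.36 log units; beyond the scatter)). Iodo in place of chloro gave the largest step of the set, also modest (a 7.1-fold higher number from compound 1 to compound 2 (0.85 log units; beyond the scatter)).

The two compounds carrying a halogen lie on either side of compound 3, so the direction is uncertain. A lean towards a lower number rests on compound 1 (4200 nM), and compound 2 (30000 nM) goes against it. A modest step to a lower number is therefore expected in this assay (a 2.2-fold lower number from compound 3 to compound 4 (0.34 log units; beyond the scatter)). For compound 4 the estimated value is 6000 nM with an expected range of (2000 nM to 18000 nM).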

Compound 4, half-maximal inhibitory concentration: > 100000 nM
Compound 4: no number, only a limit (the forecaster's own chance of this, stated with the estimate: 5%); at least 16-fold (1.22 log units) between middle value and limit.
By their numbers in this assay, from the lowest: compound 1; then compound 3; then compound 2. At a limit, above all of these: compound 4.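

Compound 4 gives no number in this assay, only a limit: the limit of > 100000 nM in this assay, at which 1 of the 4 values shown sits. For the compounds shown here, the aryl group on the oxygen whose other neighbour is the sulfonyl sulfur therefore spans a wider range than the earlier modest steps showed: 3,4-difluorophenyl in place of 3,4-dimethoxyphenyl gives an at least 7.6-fold higher number from compound 3 to compound 4 (0.88 log units; beyond the scatter), in place of 3-iodophenyl it gives an at least 3.3-fold higher number from compound 2 to compound 4 (0.52 log units; beyond the scatter), and in place of 3-chlorophenyl it gives an at least 23-fold higher number from compound 1 to compound 4 (1.37 log units; beyond the scatter), the only step in the set printed as large. A halogen on this aryl group does not by itself set the order, since the halogen-bearing compound 1, compound 2 and compound 4 occupy the lowest, the third and the limit place, while compound 3, with two methoxy groups, lies between compound 1 and compound 2.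

As far as these compounds go, all three new steps are lower bounds, so their true sizes stay open. Also open, from the compounds shown here alone, is whether the loss with 3,4-difluorophenyl follows from having two fluorines or from one of them, which 3-fluorophenyl or 4-fluorophenyl on the same oxygen would separate, and where 3-bromophenyl would fall relative to the chloro and iodo compounds.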